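Replacing 2-methoxyphenyl with 4-isopropylphenyl on a shared core

This account rests on a few compounds, and the source may have more. Where it says the series, first, only, none or still open, it means among the compounds named here.

Compounds measured in a functional assay, read by spectrophotometry, tested at 100 uM (on this read-out lower numbers stand for stronger inhibition and higher numbers for weaker inhibition), so far:
- Compound 1 `CN(C)c1ccc(/C=C/C(=O)c2cccc(NC(=O)c3cc(-c4ccncc4)n[nH]3)c2)cc1` gives 60900 nM
- Compound 2 `COc1ccccc1/C=C/C(=O)c1cccc(NC(=O)c2cc(-c3ccncc3)n[nH]2)c1` gives 56700 nM

Among the compounds with values here, compound 2 stands level with the only other value, within the scatter. Compound 3 `CC(C)c1ccc(/C=C/C(=O)c2cccc(NC(=O)c3cc(-c4ccncc4)n[nH]3)c2)cc1` is defined by one change, (4-isopropylphenyl in place of 2-methoxyphenyl on a double-bonded chain carbon bound to a double-bonded chain carbon), which puts 4-isopropylphenyl in place of 2-methoxyphenyl. Within the data shown here, compound 2 offers the only measured step at this place, a 1.1-fold lower number from compound 1 to compound 2 (0.03 log units; within the scatter), and that step stays within the scatter. No step beyond the scatter is therefore expected in this assay, though one step is thin evidence. The estimated step is small (a 1.0-fold lower number from compound 2 to compound 3 (0.01 log units; within the scatter)). Compound 3 is expected at 55000 nM, with an estimated range of 25000 nM to 100000 nM.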

Compound 3, half-maximal inhibitory concentration: 60200 nM
Compound 3: the middle estimate sits 1.1-fold (0.04 log units) below what was measured, within the range that was stated.
By their numbers in this assay, from the lowest: compounds 2, 3 and 1 (each within the scatter of the next).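

In this assay putting 4-isopropylphenyl in place of 2-methoxyphenyl gives a 1.1-fold higher number from compound 2 to compound 3 (0.03 log units; within the scatter) and putting isopropyl in place of dimethylamino on an aromatic carbon gives a 1.0-fold lower number from compound 1 to compound 3 (0.01 log units; within the scatter) and so neither step leaves the scatter. The loss of the one hydrogen-bond acceptor of 2-methoxyphenyl, with none in 4-isopropylphenyl, thus comes with no separation at this place. Nothing on hand offers a reason for this flat result.

As far as these compounds go, whether a carboxylic acid or a cyclohexyl group in place of these substituted phenyl groups would move the number beyond the scatter stays open.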